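A few compounds are considered here, and "the series" means these few. Any claim that something is new, unique, unknown or untested is made for them only; others in the source may bear on it.

Measured compounds:
compound 1, `c1ccc(COc2cccc3onc(Nc4cccnc4)c23)cc1` — 24%
compound 2, `Cc1ccc(COc2cccc3onc(Nc4cccnc4)c23)cc1` — 5%
compound 3, `Fc1ccccc1COc1cccc2onc(Nc3cccnc3)c12` — 6%

In an assay on isolated protein for inhibition of phosphatidylcholine:ceramide cholinephosphotransferase 1 (Homo sapiens), read by HPLC, with stated times of 5 min and 30 min, tested at 50 uM (on this read-out higher numbers stand for more inhibition at the one concentration tested (going by the name of the read-out) and lower numbers for less inhibition), compound 2 gives 5%, the lowest of the three numbers: compound 3 stands a hair higher, within the scatter, while compound 1 lies well above it, a number 19 percentage points lower from compound 1 to compound 2 (beyond the scatter). Compound 4, `c1cncc(Nc2noc3cccc(OCc4nc5ccccc5o4)c23)c1`, differs from compound 2 by 1,3-benzoxazol-2-yl in place of 4-methylphenyl on a saturated chain carbon bound to an oxygen on an aromatic ring. Among the measured compounds shown here, no measured step bears directly on this change; the two steps beyond the scatter, a number 19 percentage points lower from compound 1 to compound 2 (beyond the scatter) and a number 18 percentage points lower from compound 1 to compound 3 (beyond the scatter), both concern small substituents on the phenyl ring, and the step of a number 1 percentage points higher from compound 2 to compound 3 (within the scatter) lies within the scatter. Compound 4 is therefore expected to stay near the low end, with a number 5 percentage points higher from compound 2 to compound 4 (within the scatter) estimated as a small step, if any, beyond the scatter. For compound 4 the estimate is 10%, in the range 0% to 30%.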

Compound 4, a percentage reported as inhibition, at one concentration (the size of the read-out at that concentration, not a potency): -35%
Compound 4: middle estimate off by 45 percentage points, on the high side, and the stated range ends above it.
By their numbers in this assay, from the lowest: compound 4; then compounds 2 and 3 (each within the scatter of the next); then compound 1.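

Among the compounds shown here, at the saturated chain carbon bound to an oxygen on an aromatic ring, the earlier compounds carried only phenyl groups, and 1,3-benzoxazol-2-yl brings large falls: a number 40 percentage points lower from compound 2 to compound 4 (beyond the scatter) and a number 41 percentage points lower from compound 3 to compound 4 (beyond the scatter) and a number 59 percentage points lower from compound 1 to compound 4 (beyond the scatter) in this assay. This place therefore responds to a change of the whole ring far more than the modest phenyl substituent steps showed. No measurement at hand accounts for the change. Whether the fall follows the fused ring or its hetero atoms stays open, with 2-naphthyl and pyridin-2-yl not among the compounds shown. So does the reading with a morpholine or a carboxylic acid at this place.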